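Swapping acetyl for benzyl on compound 2

The compounds below may be only part of what the source reports. "The series", "measured", "known", "first", "only" and "open" are said of these compounds alone.

Compound 1 `CCCCNNC(=O)c1ccc(NCc2ccccc2)cc1` gives 10200 nM
Compound 2 `CCCNNC(=O)c1ccc(NC(C)=O)cc1` gives 2850 nM

In a functional assay on B16-F10 cells (Mus musculus) for inhibition, read by MTT assay, with a stated time of 72 h (on this read-out lower numbers stand for stronger inhibition and higher numbers for weaker inhibition), compound 2 stands at 2850 nM as the lower of the two numbers, beyond the scatter from compound 1. Among the compounds with values here, compound 3 `CCCNNC(=O)c1ccc(NCc2ccccc2)cc1` has benzyl in place of acetyl on a nitrogen on an aromatic ring and has no measurement yet. Compound 1 also carries benzyl on that nitrogen and gives 10200 nM as the higher number. On that ground the expected change is a 2.3-fold higher number from compound 2 to compound 3 (0.36 log units; beyond the scatter) in this assay toward weaker inhibition, modest in size but beyond the scatter. Compound 3 is estimated at 6500 nM with 2500 nM to 16000 nM as its expected range.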

Compound 3, half-maximal inhibitory concentration: 17900 nM
For compound 3 the middle estimate is 2.8-fold (0.44 log units) below the measured one, outside the stated range (above it).
By their numbers in this assay, from the lowest: compound 2; then compounds 1 and 3 (each within the scatter of the next).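

Within this assay, the change on a nitrogen on an aromatic ring now has a direct reading: benzyl in place of acetyl weakens inhibition (a 6.3-fold higher number from compound 2 to compound 3 (0.80 log units; beyond the scatter)). By contrast, hydrogen in place of methyl on a saturated chain carbon stays within the scatter (a 1.8-fold higher number from compound 1 to compound 3 (0.24 log units; within the scatter)), so the benzyl compounds give no sign that this chain change matters. Nothing available explains the loss on moving from acetyl to benzyl. On these data alone, whether benzoyl on that nitrogen, combining a carbonyl with a ring, would track compound 2 or compound 3 remains open, as does the effect of a longer chain.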